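Oral exposure notes: acyl variation on the shared core

The source may report more compounds than this note shows. Statements on the series, on what has been measured and on what is new or still open speak of the compounds shown alone.

Measured so far, in an ADME assay on the whole organism for pharmacokinetics, with Mus musculus as the target, read by LC-MS, using cassette dosing, with a stated time of 8 h, at a dose of 1 mg/kg by the oral route; a higher number here means more compound in the circulation at the dose given, a lower number less compound in the circulation: compound 1 `COc1ccc2c(c1)CCN(C(=O)c1cc(O)no1)[C@H]2C(=O)Nc1cc(F)c([Si](C)(C)C)c(F)c1` gives 200000 ng.h/mL; compound 2 `COc1ccc2c(c1)CCN(C(=O)CCCC(=O)O)[C@H]2C(=O)Nc1cc(F)c([Si](C)(C)C)c(F)c1` gives 6890000 ng.h/mL.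

Compound 1 stands lowest of the two numbers; its nearest neighbour is compound 2, reached by a 34-fold higher number from compound 1 to compound 2 (1.54 log units; beyond the scatter). Compound 3 `COc1ccc2c(c1)CCN(C(=O)CC(C)(C)CC(=O)O)[C@H]2C(=O)Nc1cc(F)c([Si](C)(C)C)c(F)c1` differs from compound 1 as follows: 2-(carboxymethyl)-2-methylpropyl in place of 3-hydroxy-1,2-oxazol-5-yl on a carbonyl carbon. Going by the values given here, the only step that bears on this change is a 34-fold higher number from compound 1 to compound 2 (1.54 log units; beyond the scatter), which likewise puts a carboxy-bearing chain on the same carbonyl carbon, and it was large. A comparable upward step is therefore expected, a 20-fold higher number from compound 1 to compound 3 (1.30 log units; beyond the scatter). Compound 3 is estimated at 4000000 ng.h/mL, in the range 1000000 ng.h/mL to 12000000 ng.h/mL.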

Compound 3, area under the concentration-time curve: 2270000 ng.h/mL
The estimate for compound 3 lay 1.8-fold (0.25 log units) above the measured number, and the stated range covers the measured number.
By their numbers in this assay, from the lowest: compound 1; then compound 3; then compound 2.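

In this assay a second carboxy-bearing chain on the carbonyl carbon also gives a large rise over the 3-hydroxy-1,2-oxazol-5-yl group (an 11-fold higher number from compound 1 to compound 3 (1.05 log units; beyond the scatter)), so the upward step is not confined to compound 2. The chain itself also counts: 1-(carboxymethyl)-1-methylethyl in place of 2-carboxyethyl gives a modest drop (a 3.0-fold lower number from compound 2 to compound 3 (0.48 log units; beyond the scatter)), which places compound 3 between compound 1 and compound 2. Nothing available here accounts for either step.

Still open, as far as these compounds go, is whether the carboxylic acid is required. A methyl ester, a primary amide or a longer chain ending in the acid would separate the acid from the chain that carries it.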